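The source may report more compounds than this note shows. Statements on the series, on what has been measured and on what is new or still open speak of the compounds shown alone.

Compound 1 `Cc1cc(S(=O)(=O)/N=C(\N)N/N=C/C#Cc2ccccc2)c(SCc2ccccc2C)cc1Cl` and compound 2 `C/C(C#Cc1ccccc1)=N\N/C(N)=N/S(=O)(=O)c1cc(C)c(Cl)cc1SCc1cccc(C(F)(F)F)c1` share one core and differ at the benzyl sulfanyl group and at the hydrazone carbon. In a functional assay on HCT-116 cells (Homo sapiens) for antiproliferative activity, read by MTT assay, with a stated time of 72 h (on this read-out lower numbers stand for stronger inhibition and higher numbers for weaker inhibition), compound 1 gives 19000 nM, the higher of the two numbers at hand. In this assay compound 2 gives 14000 nM, and the gap between compound 2 and compound 1 lies within the scatter of repeated measurements, so no order can be read from it. Compound 3 `Cc1cc(S(=O)(=O)/N=C(\N)N/N=C/C#Cc2ccccc2)c(SCc2ccc(C(F)(F)F)cc2)cc1Cl` has not been measured in this assay. It differs from compound 1 in one place: 4-(trifluoromethyl)phenyl in place of 2-methylphenyl on a saturated chain carbon bound to a sulfur. Within the data shown here, no pair of measured compounds isolates this change; the only guide is that compound 2, which also carries a trifluoromethyl-bearing benzyl group among other differences, sits close to compound 1. On that basis the change is expected to stay within the scatter: a 1.3-fold lower number from compound 1 to compound 3 (0.10 log units; within the scatter). Compound 3 is therefore estimated at 15000 nM, with a range from 6000 nM to 40000 nM.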

Compound 3, half-maximal inhibitory concentration: 70000 nM
Beside the measured number, compound 3's estimate is 4.7-fold (0.67 log units) below it, and the stated range ends below it.
By their numbers in this assay, from the lowest: compounds 2 and 1 (each within the scatter of the next); then compound 3.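

In this assay, among these compounds, replacing 2-methylphenyl with 4-(trifluoromethyl)phenyl on a saturated chain carbon bound to a sulfur gives a 3.7-fold higher number from compound 1 to compound 3 (0.57 log units; beyond the scatter), the only step here that isolates a single place. It shows that this position is not indifferent to the aryl group it carries, with the change weakening inhibition modestly in this one pair. Nothing available explains this step.

The pair changes both the substituent and its location on the ring at once, so it remains open which of the two accounts for the higher number. Also open, on these data alone, is how a plain benzyl group, or an amine or carboxylic acid on that ring, would behave at this position in this assay.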